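This account rests on a few compounds, and the source may have more. Where it says the series, first, only, none or still open, it means among the compounds named here.

Compound 1 `CC(C)[C@H](C[C@H]1OC(=O)NC1=O)c1ccc(-c2ccc3cccc(F)c3c2)[nH]c1=O` carries a 2,4-dioxo-1,3-oxazolidin-5-yl group on a saturated chain carbon. In an ADME assay on microsomes from liver (Homo sapiens) for metabolic stability (a higher number here means that the compound lasts longer, a lower number that the compound disappears faster), compound 1 gives 1.68 h, which is the higher of the two plain numbers recorded. The nearest neighbour is compound 3 `CC(C)C(c1ccc(-c2ccc3cccc(F)c3c2)[nH]c1=O)C1C(=O)NC(=O)N1C`, a compound of different build around the same core, which in this assay gives 0.375 h, and the gap between these two values lies beyond the scatter of the measurement. Compound 2 `CC(C)/C(=C1\C(=O)NC(=O)N1C)c1ccc(-c2ccc3cccc(F)c3c2)[nH]c1=O` in this assay gives > 3 h, which is a limit of the assay and not a number. That reading is the limit of > 3 h in this assay, at which 1 of the 3 values shown sits.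

Compound 4 `CC(C)[C@H](C[C@H]1SC(=O)NC1=O)c1ccc(-c2ccc3cccc(F)c3c2)[nH]c1=O` has not yet been measured. It differs from compound 1 in one place: 2,4-dioxo-1,3-thiazolidin-5-yl in place of 2,4-dioxo-1,3-oxazolidin-5-yl on a saturated chain carbon, two bonds along the chain from an aromatic carbon. Among the compounds with values here, no measured pair shows what exchanging a ring oxygen for a ring sulfur in this position does in this assay, so the expectation rests on compound 1 alone, with its value of 1.68 h. The step from compound 1 to compound 4 is expected to be small, a 1.0-fold higher number from compound 1 to compound 4 (0.01 log units; within the scatter), and to stay within the usual scatter. In this assay compound 4 is therefore estimated at 1.7 h, with a plausible range from 0.8 h to 3 h.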

Compound 4, half-life in the Homo sapiens assay: 0.67 h
The estimate for compound 4 lay 2.5-fold (0.40 log units) above the measured number; measured number outside the range, below it.
By their numbers in the Homo sapiens assay, from the lowest: compounds 3 and 4 (each within the scatter of the next); then compound 1. At a limit, above all of these: compound 2.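

This is the one pair shown that differs in a single place, and it shows that the ring atom at this position matters: in the Homo sapiens assay, putting 2,4-dioxo-1,3-thiazolidin-5-yl in place of 2,4-dioxo-1,3-oxazolidin-5-yl on a saturated chain carbon gives a 2.5-fold lower number from compound 1 to compound 4 (0.40 log units; beyond the scatter). In a physicochemical assay for solubility, in phosphate buffer, measured as kinetic solubility (on this read-out lower numbers stand for lower solubility and higher numbers for higher solubility), compound 1 gives 35400 nM and compound 4 gives 31200 nM, two values within the scatter of each other, so this read-out does not separate the pair. The two groups have the same ring size and the same counts of hydrogen-bond donors and acceptors, yet they are not interchangeable in the Homo sapiens assay, although the step is only modest.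

No measurement shown explains why the exchange of ring oxygen for ring sulfur goes with this shorter half-life. Also open, as far as these compounds go, is how the Homo sapiens assay would respond to other groups at this place, such as a carboxylic acid or an amine on the same saturated chain carbon, since the pair covers only these two rings.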